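A few compounds are considered here, and "the series" means these few. Any claim that something is new, unique, unknown or untested is made for them only; others in the source may bear on it.

Measured compounds:
compound 1 `c1ccc(-c2cn3ccnc3c(-c3ccc4ncn(C5CCCCC5)c4c3)n2)cc1` — 59.8%
compound 2 `Brc1ccc(-c2cn3ccnc3c(-c3ccc4ncn(C5CCCCC5)c4c3)n2)cc1` — 60.7%
compound 3 `COc1ccccc1-c1cn2ccnc2c(-c2ccc3ncn(C4CCCCC4)c3c2)n1` — 26.3%

In a functional assay on SR cells (Homo sapiens) for inhibition, read by sulforhodamine B assay, with a stated time of 48 h, tested at 10 uM (a higher number here means more inhibition at the concentration tested (going by the name of the read-out), a lower number less inhibition), compound 1 gives 59.8%, the second highest of the three numbers. The step of a number 0.9 percentage points higher from compound 1 to compound 2 (within the scatter) shows that a substituent on the phenyl can leave the read-out unchanged, whereas a number 33.5 percentage points lower from compound 1 to compound 3 (beyond the scatter) and a number 34.4 percentage points lower from compound 2 to compound 3 (beyond the scatter) show that another substituent pulls it down sharply.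

Compound 4 `FC(F)(F)c1cccc(-c2cn3ccnc3c(-c3ccc4ncn(C5CCCCC5)c4c3)n2)c1` differs from compound 1 by trifluoromethyl in place of hydrogen on an aromatic carbon; cut one bond further out, this reads phenyl to 3-(trifluoromethyl)phenyl. Among the measured compounds shown here, no measured step introduces a trifluoromethyl, so the two phenyl-substitution steps are the only guides: one flat, one a large fall. A step in this assay of modest size downward, or none beyond the scatter, is therefore expected, with the drop seen for compound 3 marking the lower edge of what seems plausible.

Compound 4 is estimated to give 50%, range 25% to 70%, corresponding to an expected step of a number 9.8 percentage points lower from compound 1 to compound 4 (within the scatter).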

Compound 4, a percentage reported as inhibition, at one concentration (the size of the read-out at that concentration, not a potency): 15.6%
Compound 4: the middle estimate sits 34.4 percentage points above what was measured; measured number below the stated range.
By their numbers in this assay, from the lowest: compound 4; then compound 3; then compounds 1 and 2 (each within the scatter of the next).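

In this assay a number 44.2 percentage points lower from compound 1 to compound 4 (beyond the scatter) and a number 45.1 percentage points lower from compound 2 to compound 4 (beyond the scatter) show that a large fall on substituting this phenyl is not confined to methoxy, and trifluoromethyl, meta to a large group, gives the lowest number in the set. Compound 2 goes against any general rule that substitution here lowers the read-out. The a number 10.7 percentage points lower from compound 3 to compound 4 (beyond the scatter) is modest but beyond the scatter, which sets 3-(trifluoromethyl)phenyl under 2-methoxyphenyl, and nothing at hand offers an explanation for either fall.

Open, from the compounds shown here alone, is whether the fall follows the group itself or its place on the ring, as each substituent appears at one place only. Also open, going by these compounds, is whether an amine or a carboxylic acid on this phenyl would hold the read-out as bromo does or lower it.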